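The source may hold more compounds than are shown below. What is called first, only, known or untested is meant among the compounds shown, and "the series" means these compounds.

In a functional assay on A549 cells (Homo sapiens) for antiproliferative activity, read by sulforhodamine B assay, with a stated time of 48 h (a lower number here means a stronger inhibitor, a higher number a weaker inhibitor), compound 1 `COc1cc(C=C(C(=O)/C=C/c2cccc(OC)c2OC)C(=O)/C=C/c2cccc(OC)c2OC)ccc1O` gives 130 nM and compound 2 `COc1cc(C=C(C(=O)/C=C/c2cccc(OC)c2OC)C(=O)/C=C/c2cccc(OC)c2OC)cc(Br)c1O` gives 200 nM. With only these two measured, compound 2 stands level with compound 1, since a 1.5-fold higher number from compound 1 to compound 2 (0.19 log units; within the scatter) does not separate them. Compound 3 `COc1cc(C=C(C(=O)/C=C/c2cccc(OC)c2OC)C(=O)/C=C/c2cccc(OC)c2OC)cc(OC)c1O` has not yet been measured. It carries methoxy in place of bromo on an aromatic carbon, ortho to a hydroxy group: methoxy in place of bromo on an aromatic carbon. For the measured compounds named here, only one measured step bears on this carbon, where bromo took the place of hydrogen, and that step is a 1.5-fold higher number from compound 1 to compound 2 (0.19 log units; within the scatter). Going by the values given here, no measured compound shows what methoxy does at this carbon, so the evidence is thin. Even so, no step beyond the scatter is expected in this assay. The estimate amounts to a 1.2-fold lower number from compound 2 to compound 3 (0.07 log units; within the scatter), an expected step that stays within the scatter. For compound 3 the expected value is 170 nM, with an estimated range of 80 nM to 380 nM.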

Compound 3, half-maximal inhibitory concentration: 240 nM
For compound 3 the middle estimate is 1.4-fold (0.15 log units) below the measured one; the range from low to high includes it.
By their numbers in this assay, from the lowest: compounds 1, 2 and 3 (each within the scatter of the next).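

In this assay, placing methoxy on the aromatic carbon ortho to a hydroxy group gives a 1.2-fold higher number from compound 2 to compound 3 (0.08 log units; within the scatter) when it replaces bromo, and a 1.8-fold higher number from compound 1 to compound 3 (0.27 log units; within the scatter) when it replaces hydrogen. This carbon has now carried three different substituents, hydrogen, bromo and methoxy, and no listed step between them goes beyond the scatter, even though methoxy brings a hydrogen-bond acceptor that bromo does not. No supporting measurement is available to explain this result.

The compounds shown leave open whether a charged or much larger group at this carbon, such as an amine, a carboxylic acid or a longer alkoxy chain, would also stay within the scatter. All three compounds also keep the hydroxy group, so replacing it with a methoxy or a fluoro group remains an open question.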